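Replacing Piperazine with Methylamino on the Shared Core

The source may hold more compounds than are shown below. What is called first, only, known or untested is meant among the compounds shown, and "the series" means these compounds.

Compound 3 `O=C(NCc1ccc(F)cc1)c1nc(Br)c2cccnc2c1N1CCNCC1` carries a piperazin-1-yl group on the shared core. In a functional assay on HCT-116 cells (Homo sapiens) for cytotoxicity, read by MTT assay, with a stated time of 72 h (on this read-out higher numbers stand for weaker inhibition and lower numbers for stronger inhibition), compound 3 gives > 10000 nM, which is a limit of the assay. Compound 1 `O=C(NCc1ccc(F)cc1)c1nc(Br)c2cccnc2c1NCc1ccccc1` gives > 20000 nM in this assay, also a limit. Compound 2 `CNCCCNc1c(C(=O)NCc2ccc(F)cc2)nc(Br)c2cccnc12` gives > 10000 nM, again a limit. Due to the limit of > 10000 nM in this assay, at which 2 of the 3 values shown sit, and (the limit of > 20000 nM in this assay, at which 1 of the 3 values shown sits), the steps a step that the two limits leave unreadable from compound 1 to compound 3 and a step that the two limits leave unreadable from compound 2 to compound 3 cannot be read for size or direction. Compound 4 `CNc1c(C(=O)NCc2ccc(F)cc2)nc(Br)c2cccnc12` differs from compound 3 by methylamino in place of piperazin-1-yl on an aromatic carbon. Among the compounds with values here, no measured step bears on this change, so no shift beyond the scatter is expected in this assay, and another limit is the likeliest outcome. Compound 4 is estimated at 20000 nM, within 5000 nM to 60000 nM. The expected step is therefore a step that the limit leaves unreadable from compound 3 to compound 4.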

Compound 4, half-maximal inhibitory concentration: > 20000 nM
Compound 4: a limit, no number; the forecaster's own chance of this, stated with the estimate: 75%; the middle value lies on the limit itself.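

Within the data shown here, compound 1, compound 2, compound 3 and compound 4 all give limits, not numbers, in this assay; no step among them can be read for size or direction. From the compounds shown here alone, how strongly any of them inhibits remains open.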